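The source may report more compounds than this note shows. Statements on the series, on what has been measured and on what is new or still open speak of the compounds shown alone.

In a functional assay on UACC-257 cells (Homo sapiens) for inhibition, read by sulforhodamine B assay, with a stated time of 48 h (on this read-out lower numbers stand for stronger inhibition of growth and higher numbers for weaker inhibition of growth), compound 1 `O=C(Cc1csc2nc(-c3ccc(Br)cc3)cn12)N/N=C/c1ccccc1` gives 6170 nM and compound 2 `O=C(Cc1csc2nc(-c3ccc(Br)cc3)cn12)N/N=C/c1ccccc1O` gives 3720 nM (two numbers within the scatter of each other, and the only ones so far). Compound 3 `O=C(Cc1csc2nc(-c3ccc(Br)cc3)cn12)N/N=C/c1ccc(O)cc1` differs from compound 2 in one place: 4-hydroxyphenyl in place of 2-hydroxyphenyl on a carbon with a double bond to nitrogen. Among the compounds with values here, the only measured step that bears on this, the addition of a hydroxy group (a 1.7-fold lower number from compound 1 to compound 2 (0.22 log units; within the scatter)), stayed within the scatter, so no change beyond the scatter is expected in this assay here. The expected step is small (a 1.1-fold higher number from compound 2 to compound 3 (0.03 log units; within the scatter)). For compound 3 the estimated value is 4000 nM (expected range 1800 nM to 9000 nM).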

Compound 3, concentration for 50% growth inhibition: 1510 nM
Beside the measured number, compound 3's estimate is 2.6-fold (0.42 log units) above it; the whole stated range lies above it.
By their numbers in this assay, from the lowest: compound 3; then compounds 2 and 1 (each within the scatter of the next).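

In this assay, where the hydroxy group sits on the ring now makes a difference: 4-hydroxyphenyl in place of 2-hydroxyphenyl, with the same atoms, gives a 2.5-fold lower number from compound 2 to compound 3 (0.39 log units; beyond the scatter). Adding hydroxy as 4-hydroxyphenyl also gives a 4.1-fold lower number from compound 1 to compound 3 (0.61 log units; beyond the scatter), a step beyond the scatter, unlike the addition as 2-hydroxyphenyl. No measurement given here explains why the placement matters.

Still open, as far as these compounds go, is whether this gain needs the hydroxy group itself, or whether a methoxy group or an amine in its place would give a similar number.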